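The source may hold more compounds than are shown below. What is called first, only, known or untested is meant among the compounds shown, and "the series" means these compounds.

Measured so far in a physicochemical assay for solubility, read by HPLC, in phosphate buffer, measured as kinetic solubility, at pH 7.4; on this read-out lower numbers stand for lower solubility and higher numbers for higher solubility:
Compound 1 `CC[C@@H](C)n1ncn(-c2ccc(N3CCN(c4ccc(OC[C@@H]5CO[C@@](C)(c6ccc(Cl)cc6Cl)O5)cc4)CC3)cc2)c1=O` gives 1560 nM
Compound 2 `C[C@@]1(c2ccc(Cl)cc2Cl)OC[C@@H](COc2ccc(N3CCN(c4ccc(NC(=O)c5cccnc5)cc4)CC3)cc2)O1` gives 4.2 nM
Compound 3 `C[C@]1(c2ccc(Cl)cc2Cl)OC[C@@H](COc2ccc(N3CCN(c4ccc(NC(=O)c5cccnc5)cc4)CC3)cc2)O1` gives 6.9 nM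

Compound 2 and compound 3 lie within the scatter of each other at the low end of these numbers, far under compound 1. Compound 4 `C[C@@]1(c2ccc(Cl)cc2Cl)OC[C@@H](COc2ccc(N3CCN(c4ccc(NC(=O)NN)cc4)CC3)cc2)O1` differs from compound 2 by aminoamino in place of pyridin-3-yl on a carbonyl carbon, with aminoamino in place of pyridin-3-yl on a carbonyl carbon. The measured 1.6-fold higher number from compound 2 to compound 3 (0.22 log units; within the scatter) reflects the fact that compounds 2 and 3 differ only in the configuration as drawn and does not involve this group. The other measured step, a 370-fold lower number from compound 1 to compound 2 (2.57 log units; beyond the scatter), is large and exchanges a ring-bearing group, so the number can move strongly on such a change. A smaller rise is expected here, with the direction less certain: a 6.0-fold higher number from compound 2 to compound 4 (0.77 log units; beyond the scatter) as estimated. For compound 4 the expected value is 25 nM, within an estimated range of 4 nM to 150 nM overall.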

Compound 4, solubility: 9.3 nM
For compound 4 the middle estimate is 2.7-fold (0.43 log units) above the measured one, and the stated range covers the measured number.
By their numbers in this assay, from the lowest: compounds 2, 3 and 4 (each within the scatter of the next, the first and the last beyond it); then compound 1.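

In this assay, the carbonyl carbon takes aminoamino in place of pyridin-3-yl with only a modest move (a 2.2-fold higher number from compound 2 to compound 4 (0.35 log units; beyond the scatter)). Even with no ring in this group, the gap to the earlier high value stays large (a 170-fold lower number from compound 1 to compound 4 (2.22 log units; beyond the scatter)). Nothing measured here accounts for either step.

What the compounds shown leave open is how the number would respond to a simple amine or a longer chain on this carbonyl carbon. They also leave open whether aminoamino would give a similar number with the other drawn configuration.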